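The source may hold more compounds than are shown below. What is called first, only, known or untested is meant among the compounds shown, and "the series" means these compounds.

Compound 1 `CCOC(=O)c1oc2ccc(NS(=O)(=O)c3ccc(Cl)cc3)cc2c1C` stands at the top of the three measured numbers: in a functional assay on MCF7 cells (Homo sapiens) for antiproliferative activity, read by MTT assay, with a stated time of 72 h (on this read-out higher numbers stand for weaker inhibition and lower numbers for stronger inhibition), compound 1 gives 81200 nM. Compound 2 `CCOC(=O)c1oc2ccc(NS(=O)(=O)c3ccc(C(F)(F)F)cc3)cc2c1C` gives 48700 nM and compound 3 `CCOC(=O)c1oc2ccc(NS(=O)(=O)c3ccc(C(C)(C)C)cc3)cc2c1C` gives 22100 nM. The step of a 1.7-fold lower number from compound 1 to compound 2 (0.22 log units; within the scatter) is small, whereas a 3.7-fold lower number from compound 1 to compound 3 (0.57 log units; beyond the scatter) and a 2.2-fold lower number from compound 2 to compound 3 (0.34 log units; beyond the scatter) are modest. Compound 4 `CCOC(=O)c1oc2ccc(NS(=O)(=O)c3cccs3)cc2c1C` differs from compound 1 by thiophen-2-yl in place of 4-chlorophenyl on a sulfonyl sulfur. The measured steps each swap one group on the six-membered ring, and the tert-butyl of compound 3 gave the lowest number; none of them replaces the ring itself, so they bear only loosely on this change. With the ring gone and a bare thiophen-2-yl entering, the expected step of a 1.2-fold higher number from compound 1 to compound 4 (0.09 log units; within the scatter) is small, if anything towards a higher number. Compound 4 is therefore estimated at 100000 nM, within 40000 nM to 250000 nM.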

Compound 4, half-maximal inhibitory concentration: 92300 nM
The estimate for compound 4 lay 1.1-fold (0.03 log units) above the measured number; low and high end bracket the measured number.
By their numbers in this assay, from the lowest: compound 3; then compounds 2, 1 and 4 (each within the scatter of the next).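

The step of a 1.1-fold higher number from compound 1 to compound 4 (0.06 log units; within the scatter) shows that, in this assay, the whole 4-chlorophenyl on the sulfonyl sulfur can give way to thiophen-2-yl with no difference beyond the scatter. Within the data shown here, the earlier compounds changed only one group on the six-membered ring, whereas here the ring itself is exchanged, and a five-membered ring with a hetero atom serves equally well on this read-out. Nothing measured here offers an explanation for this match. Still open, as far as these compounds go, is whether a ring is needed here at all, as a plain butyl chain or an amine-bearing group on the sulfonyl sulfur would test. From the compounds shown here alone, it is also open whether a tert-butyl on the thiophen-2-yl would matter as it does on the six-membered ring.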